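The source may hold more compounds than are shown below. What is called first, only, known or untested is meant among the compounds shown, and "the series" means these compounds.

In an in vivo ADME assay on the whole organism (strain Sprague-Dawley) for pharmacokinetics, with Rattus norvegicus as the target, at a dose of 5 mg/kg by the oral route (a higher number here means that a larger share of the oral dose reaches the circulation, a lower number that a smaller share of the oral dose reaches the circulation), three compounds sharing one core have been measured. Compound 1 `COc1cc(C2CCN(C[C@@H](C)O)CC2)ccc1Nc1ncc2ccc(-c3ccccc3OC)n2n1` gives only a limit of the assay, < 1%. Compound 2 `COc1cc(C2CCN(CC(N)=O)CC2)ccc1Nc1ncc2ccc(-c3ccccc3OC)n2n1` gives 43%. Between these two the single change, carbamoyl in place of 1-hydroxyethyl on a saturated chain carbon bound to an amine nitrogen in a ring, goes with a number at least 42 percentage points higher from compound 1 to compound 2 (beyond the scatter), a large step. Compound 3 `COc1cc(C2CCN(CC(N)=O)CC2)ccc1Nc1ncc2c(C)cc(-c3ccccc3N(C)S(C)(=O)=O)n2n1` gives 24%. Of the two numbers shown, compound 3 stands lowest, with compound 2 the nearest and higher by a gap beyond the scatter; the third value is a limit rather than a number.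

Compound 4 `COc1cc(C2CCN(CC(N)=O)CC2)ccc1Nc1ncc2c(Cl)cc(-c3ccccc3N(C)S(C)(=O)=O)n2n1` has not yet been measured. It differs from compound 3 in one place: chloro in place of methyl on an aromatic carbon. For the measured compounds named here, the only measured step, a number at least 42 percentage points higher from compound 1 to compound 2 (beyond the scatter), concerns the chain on the amine nitrogen in a ring, not an aromatic carbon of the fused system, so it gives no guide for this exchange. Going by the values given here, with no measured step bearing on it, the expected step is therefore no change at the digits printed from compound 3 to compound 4 (within the scatter), which is within the usual scatter. Compound 4 is estimated at 24%, with a likely range from 10% to 40%.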

Compound 4, oral bioavailability: 41%
For compound 4 the middle estimate is 17 percentage points below the measured one; the whole stated range lies below it.
By their numbers in this assay, from the lowest: compound 3; then compounds 4 and 2 (each within the scatter of the next). At a limit, below all of these: compound 1.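

The exchange of methyl for chloro on this aromatic carbon of the five-membered ring goes with a number 17 percentage points higher from compound 3 to compound 4 (beyond the scatter), so in this assay this position matters as well as the chain on the ring nitrogen, the only place where a single change could be read before. The two groups have the same count of heavy atoms, neither has hydrogen-bond donors or acceptors, and neither carries a net charge, so those counts do not separate them, yet the step lies beyond the scatter with the rest of the molecule held fixed. The step rests on this one pair, and nothing measured here accounts for it.

The compounds shown leave open how a fluoro, a bromo or a nitrile on this aromatic carbon would compare with chloro and methyl, and whether the same exchange gives a similar step when the ring atom two ring bonds away bears a group other than 2-(methyl(methylsulfonyl)amino)phenyl. A single figure for oral bioavailability also cannot tell how much of the dose was lost in uptake from the gut and how much in clearance from the body.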